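A few compounds are considered here, and "the series" means these few. Any claim that something is new, unique, unknown or untested is made for them only; others in the source may bear on it.

Measured compounds in an ADME assay on Huh-7 cells (Homo sapiens) for cytotoxicity; on this read-out higher numbers stand for lower toxicity in this test and lower numbers for higher toxicity in this test:
- compound 1 `O=c1cc(CNCc2ccccc2Br)oc2ccc(O)c(O)c12` gives > 100000 nM, a limit of the assay.
- compound 2 `Cc1ccccc1CNCc1cc(=O)c2c(O)c(O)ccc2o1` gives 52200 nM.
- compound 3 `O=c1cc(CNCc2cccc(Br)c2)oc2ccc(O)c(O)c12` gives > 100000 nM, again a limit of the assay.

Compound 3 therefore stands only at a limit in this assay, and it shares that position with one other value, as summarised in the limit of > 100000 nM in this assay, at which 2 of the 3 values shown sit. The step that the two limits leave unreadable from compound 1 to compound 3 is unreadable because both ends sit at the limit. The step of an at least 1.9-fold higher number from compound 2 to compound 3 (0.28 log units; that floor lies within the scatter) is readable only as a floor, and that floor lies within the scatter.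

Compound 4 `O=c1cc(CNCc2cccc([N+](=O)[O-])c2)oc2ccc(O)c(O)c12` differs from compound 3 by nitro in place of bromo on an aromatic carbon. For the measured compounds named here, no measured step involves a nitro group; the only change at this position with a readable floor is the step from compound 2 to compound 3, a swap of 3-bromophenyl for 2-methylphenyl, which is not the same kind of change. On these grounds no step beyond the scatter is expected in this assay, and the most likely outcome is that compound 4 again sits at the limit. The expected step of a number no higher from compound 3 to compound 4 (the limit leaves the size open) is thus none beyond the scatter. Compound 4 is estimated at 100000 nM, with a range from 40000 nM to 200000 nM.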

Compound 4, half-maximal cytotoxic concentration: > 100000 nM
Compound 4 was reported as a limit; the forecaster's own chance of this, stated with the estimate: 65%; the middle value sits exactly at the limit.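

In this assay compound 4 gives > 100000 nM, a limit of the assay. For the compounds shown here, compound 3 gives > 100000 nM, again a limit, and no step between compound 3 and compound 4 can be read. The compounds shown leave open whether nitro and bromo differ at all on this read-out, since the values stop at one ceiling: the limit of > 100000 nM in this assay, at which 3 of the 4 values shown sit.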